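The compounds below may be only part of what the source reports. "The series", "measured", "known", "first", "only" and "open" are said of these compounds alone.

Of the compounds shown here, three have been measured in an ADME assay on microsomes from liver (Mus musculus) for metabolic stability; a higher number here means faster removal of the compound, a lower number slower removal. Compound 1 `CCO[C@@H]1O[C@H](CNC(=O)c2ccc(S(N)(=O)=O)cc2)[C@@H](O)[C@H](O)[C@H]1N` gives 1.56 mL/min/kg. Compound 2 `CCCO[C@@H]1O[C@H](CNC(=O)c2ccc(S(N)(=O)=O)cc2)[C@@H](O)[C@H](O)[C@H]1N` gives 1.42 mL/min/kg; the change from compound 1 to compound 2 is methyl in place of hydrogen on a saturated chain carbon, two bonds along the chain from an oxygen on a saturated carbon, and it made the step of a 1.1-fold lower number from compound 1 to compound 2 (0.04 log units; within the scatter). Compound 3 `CCO[C@@H]1O[C@H](CNC(=O)c2ccc(S(N)(=O)=O)cc2)[C@@H](O)[C@H](O)[C@@H]1O` gives 1.48 mL/min/kg; the difference between the cores of compound 1 and compound 3 is not broken down here, and the values of compound 1, compound 2 and compound 3 all lie within the scatter of one another. Compound 4 `CCCO[C@@H]1O[C@H](CNC(=O)c2ccc(S(N)(=O)=O)cc2)[C@@H](O)[C@H](O)[C@@H]1O` is not yet measured. It differs from compound 3 by methyl in place of hydrogen on a saturated chain carbon, two bonds along the chain from an oxygen on a saturated carbon, the same change that was made at the same place in the first pair. The step expected here, a 1.1-fold lower number from compound 3 to compound 4 (0.02 log units; within the scatter), is taken to be of about that earlier size because the first occurrence gave a 1.1-fold lower number from compound 1 to compound 2 (0.04 log units; within the scatter). Compound 4 is therefore estimated at 1.4 mL/min/kg, with a range from 0.9 mL/min/kg to 2.2 mL/min/kg.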

Compound 4, clearance: 1.42 mL/min/kg
Compound 4: the middle estimate sits 1.0-fold (0.01 log units) below what was measured, and the stated range covers the measured number.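

In this assay the ethoxy to propoxy change gives a 1.0-fold lower number from compound 3 to compound 4 (0.02 log units; within the scatter) on the core of compound 3, and the two occurrences of this change agree: the same change on two cores in this assay, a 1.1-fold lower number (0.04 log units; within the scatter) from compound 1 to compound 2 and a 1.0-fold lower number (0.02 log units; within the scatter) from compound 3 to compound 4, 1.1-fold (0.02 log units) apart, within the scatter of two such steps.

The change therefore carries from the core of compound 1 to the core of compound 3 with no detectable difference in size. Within the data shown here, both steps lie within the scatter, so the pairs show only that this change does little on these two cores; they do not show that a larger step would carry over in the same way, or that the result holds on other cores.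

Open, as far as these compounds go, is whether a longer chain such as butoxy, a branched chain, or an amine at the end of the chain would move clearance beyond the scatter.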